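From naphthalene to benzofuran on a shared core

A few compounds are considered here, and "the series" means these few. Any claim that something is new, unique, unknown or untested is made for them only; others in the source may bear on it.

Measured in a functional assay on CCRF-CEM cells (Homo sapiens) for cytotoxicity, read by XTT assay, with a stated time of 3 days; on this read-out lower numbers stand for stronger inhibition and higher numbers for weaker inhibition:
- Compound 1 `C[C@@]1(O)[C@H](O)[C@@H](CO)O[C@H]1n1cc(I)c2c(N)ncnc21`: 4380 nM
- Compound 2 `C[C@@]1(O)[C@H](O)[C@@H](CO)O[C@H]1n1cc(-c2ccc3ccccc3c2)c2c(N)ncnc21`: 3950 nM

Among the compounds with values here, only two numbers are available so far, and they lie within the usual scatter of each other. Compound 2, at 3950 nM, therefore stands level with compound 1, at 4380 nM.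

The next structure is compound 3 `C[C@@]1(O)[C@H](O)[C@@H](CO)O[C@H]1n1cc(-c2cc3ccccc3o2)c2c(N)ncnc21`, which changes a single group: 1-benzofuran-2-yl in place of naphthalen-2-yl on an aromatic carbon. In plain words, 1-benzofuran-2-yl takes the place of naphthalen-2-yl on an aromatic carbon.

Within the data shown here, only one measured step bears on this change. Putting naphthalen-2-yl in place of iodo gave a 1.1-fold lower number from compound 1 to compound 2 (0.04 log units; within the scatter), a step within the scatter. That step shows a large group replacing a single atom with no clear shift in this assay. However, no compound carrying 1-benzofuran-2-yl has been measured yet, so this evidence is thin. No shift beyond the scatter is expected, and the expected size is a 1.0-fold higher number from compound 2 to compound 3 (0.01 log units; within the scatter).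

For compound 3 the estimated value is 4000 nM, with an expected range of 1500 nM to 12000 nM.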

Compound 3, half-maximal inhibitory concentration: 7810 nM
Compound 3: the middle estimate sits 2.0-fold (0.29 log units) below what was measured; low and high end bracket the measured number.
By their numbers in this assay, from the lowest: compounds 2, 1 and 3 (each within the scatter of the next).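

In this assay, 1-benzofuran-2-yl in place of naphthalen-2-yl gives a 2.0-fold higher number from compound 2 to compound 3 (0.30 log units; within the scatter) and 1-benzofuran-2-yl in place of iodo gives a 1.8-fold higher number from compound 1 to compound 3 (0.25 log units; within the scatter) on the same aromatic carbon of the shared core. Compounds 1, 2 and 3 thus form a short series in which each number lies within the scatter of the next, so this assay does not separate a single iodine atom from either of the two fused two-ring groups. The change from an all-carbon group to one with a ring oxygen and a hydrogen-bond acceptor also gives no step beyond the scatter, and no supporting measurement is available to explain the numbers.

These compounds leave open whether a group of a different kind at this position, such as an amine, a carboxylic acid or a longer chain, would move the number beyond the scatter. They also leave open how a single-ring group such as phenyl or furan-2-yl would compare with the fused two-ring groups on the same core.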